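The source may report more compounds than this note shows. Statements on the series, on what has been measured and on what is new or still open speak of the compounds shown alone.

Of the compounds shown here, three built on one shared core have been tested in an ADME assay on the whole organism for inhibition, with Oryza sativa as the target, with a stated time of 4 days; a higher number here means a weaker inhibitor, a lower number a stronger inhibitor. Compound 1 `CCN(c1nc(Cl)nc(N[C@@H](C)c2ccccc2)n1)C(C)C` gives 537 nM. Compound 2 `CC[C@@H](C)Nc1nc(Cl)nc(N[C@@H](C)c2ccccc2)n1` gives 9770 nM. Compound 3 `CCCN(CCC)c1nc(Cl)nc(N[C@@H](C)c2ccccc2)n1` gives 331 nM, the lowest number of the three; the step of a 1.6-fold lower number from compound 1 to compound 3 (0.21 log units; within the scatter) lies within the scatter, so compound 1 and compound 3 cannot be separated, whereas a 30-fold lower number from compound 2 to compound 3 (1.47 log units; beyond the scatter) is a large step.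

Compound 4 `CCC(CC)Nc1nc(Cl)nc(N[C@@H](C)c2ccccc2)n1` has not yet been measured. Its difference from compound 3 is (pentan-3-yl)amino in place of dipropylamino on an aromatic carbon. The group that enters carries a single branched chain on the amino nitrogen, as (sec-butyl)amino does in compound 2, while the group that leaves carries two chains, like dipropylamino in compound 3 and ethyl(isopropyl)amino in compound 1. Among the compounds with values here, the steps that bear on this are an 18-fold higher number from compound 1 to compound 2 (1.26 log units; beyond the scatter) and a 30-fold lower number from compound 2 to compound 3 (1.47 log units; beyond the scatter), both large and both pointing to a much higher number for the single-chain amino group. A large rise is therefore expected, roughly an 18-fold higher number from compound 3 to compound 4 (1.26 log units; beyond the scatter). Compound 4 is estimated at 6000 nM, with a range from 1500 nM to 25000 nM.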

Compound 4, half-maximal inhibitory concentration: 35500 nM
Beside the measured number, compound 4's estimate is 5.9-fold (0.77 log units) below it; the measured number lies above the stated range.
By their numbers in this assay, from the lowest: compounds 3 and 1 (each within the scatter of the next); then compound 2; then compound 4.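

In this assay, the high numbers are now seen with a second single-chain amino group, so they are not peculiar to (sec-butyl)amino: (pentan-3-yl)amino stands far above both two-chain groups (a 110-fold higher number from compound 3 to compound 4 (2.03 log units; beyond the scatter); a 66-fold higher number from compound 1 to compound 4 (1.82 log units; beyond the scatter)). The single-chain groups also differ from each other, with pentan-3-yl in place of sec-butyl on the nitrogen giving a smaller but real further rise (a 3.6-fold higher number from compound 2 to compound 4 (0.56 log units; beyond the scatter)). Nothing measured here explains these differences.

The change from dipropylamino to (pentan-3-yl)amino alters both the chains and the hydrogen-bond donor count, and these compounds cannot separate the two. A single unbranched chain such as propylamino, or two chains closed into a piperidine ring, would be needed to tell them apart.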